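The source may hold more compounds than are shown below. What is called first, only, known or untested is meant among the compounds shown, and "the series" means these compounds.

Compound 1 `CC(C)C/N=C(\NC#N)Nc1cccnc1` is the starting point of this comparison. In a functional assay on the whole organism (blood, strain Wistar-Okamoto) with Rattus norvegicus as the target, with a stated time of 5 days (on this read-out higher numbers stand for an effect only at larger amounts of compound and lower numbers for an effect already at smaller amounts), compound 1 gives 20 mg/kg. Among the two compounds that yield a number here, compound 1 stands highest; its nearest neighbour is compound 3 `CC(C)C(/N=C(\NC#N)Nc1cccnc1)C(C)C`, which gives 5 mg/kg. Going by the values given here, the only measured step that changes a single place is a 4.0-fold lower number from compound 1 to compound 3 (0.60 log units; beyond the scatter). Compound 2 `CCCCC(CC)C/N=C(\NC#N)Nc1cccnc1` gives only a limit of the assay, > 50 mg/kg. Among the compounds with values here, it is the one value sitting at the limit of > 50 mg/kg in this assay, at which 1 of the 3 values shown sits.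

The compound still to be measured, compound 4 `CCCC(C)(C)/N=C(\NC#N)Nc1cccnc1`, differs from compound 1 in one place: 1,1-dimethylbutyl in place of isobutyl on a double-bonded nitrogen. In both this change and the step to compound 3 a larger saturated group sits on the double-bonded nitrogen, and that measured step lowered the number beyond the scatter. At the same time compound 2, which also carries a larger saturated group there, gave only a limit, so the evidence points both ways. A modest lowering, or no change beyond the scatter, is the most that can be expected.

Compound 4 is therefore expected to give about 10 mg/kg, between 4 mg/kg and 30 mg/kg. This estimate means a step of a 2.0-fold lower number from compound 1 to compound 4 (0.30 log units; within the scatter).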

Compound 4, minimum effective dose: 1 mg/kg
Estimate against measurement, compound 4: 10-fold (1.00 log units) above; measured number below the stated range.
By their numbers in this assay, from the lowest: compound 4; then compound 3; then compound 1. At a limit, above all of these: compound 2.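

In this assay, going by these compounds alone, the saturated group on the double-bonded nitrogen turns out to matter far more than the earlier compounds could show: placing 1,1-dimethylbutyl there instead of isobutyl gives a 20-fold lower number from compound 1 to compound 4 (1.30 log units; beyond the scatter), a large step. Within the data shown here, the only earlier single-place step at this nitrogen, a 4.0-fold lower number from compound 1 to compound 3 (0.60 log units; beyond the scatter), was modest, so this position can move the dose needed for an effect much further than that step suggested. A larger saturated group does not lower the number in every case, and compound 2 goes against any such pattern, since it also carries a larger group here and yields no number, only a limit of the assay: the limit of > 50 mg/kg in this assay, at which 1 of the 4 values shown sits.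

With so few compounds, the result cannot separate the effect of adding carbons from the effect of how those carbons are arranged in 1,1-dimethylbutyl, and no cause for the step can be given. As far as these compounds go, it also remains open what a tert-butyl group, a cyclohexyl ring or a chain ending in a hydroxyl group or an amine would do on this nitrogen.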